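From compound 3 to compound 4: a step from a limit

This account rests on a few compounds, and the source may have more. Where it says the series, first, only, none or still open, it means among the compounds named here.

Compound 1 `NC(=O)c1c(NC(=O)c2ccccc2Cl)sc2c1CCN(Cc1c(Cl)cccc1Cl)C2`: 28800 nM
Compound 2 `NC(=O)c1c(NC(=O)c2ccc(C(F)(F)F)cc2)sc2c1CCN(Cc1ccccc1F)C2`: > 50000 nM, a limit
Compound 3 `NC(=O)c1c(NC(=O)c2ccc(C(F)(F)F)cc2)sc2c1CCN(Cc1ccc(Cl)cc1)C2`: > 50000 nM, a limit

All three compounds were tested in a functional assay on HeLa cells (Homo sapiens) for antiproliferative activity, with a stated time of 24 h; on this read-out lower numbers stand for stronger inhibition and higher numbers for weaker inhibition. Compound 3 stands at the limit of > 50000 nM in this assay, at which 2 of the 3 values shown sit, so its value is a limit and not a number. Compound 4 `NC(=O)c1c(NC(=O)c2ccc(C(F)(F)F)cc2)sc2c1CCN(Cc1c(Cl)cccc1Cl)C2` has not yet been measured. The change leading to it is 2,6-dichlorophenyl in place of 4-chlorophenyl on a saturated chain carbon bound to an amine nitrogen in a ring, with 2,6-dichlorophenyl in place of 4-chlorophenyl on a saturated chain carbon bound to an amine nitrogen in a ring. Going by the values given here, the one measured step at this place is a step that the two limits leave unreadable from compound 2 to compound 3, so it sets no size. Compound 4 differs elsewhere from compound 1, yet the shared 2,6-dichlorophenyl group makes compound 1 at 28800 nM the nearest guide. A change toward stronger inhibition is therefore expected, though it may be small, and another limit would be no surprise. The expected step is an at least 1.2-fold lower number from compound 3 to compound 4 (0.09 log units; that floor lies within the scatter). Compound 4 is estimated at 40000 nM, with an expected range of 18000 nM to 70000 nM.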

Compound 4, half-maximal inhibitory concentration: > 50000 nM
Compound 4 ended at the assay's limit; the forecaster's own chance of this, stated with the estimate: 50%; middle value at least 1.2-fold (0.09 log units) away from the limit.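

In this assay, 2,6-dichlorophenyl at this place, on a saturated chain carbon bound to an amine nitrogen in a ring, gives no measurable value when the carbonyl carbon carries 4-(trifluoromethyl)phenyl, so three different groups there now end at one limit: the limit of > 50000 nM in this assay, at which 3 of the 4 values shown sit. The steps among compound 2, compound 3 and compound 4 cannot be read, as all three values are limits. Going by these compounds alone, exchanging the group on the carbonyl carbon gives an at least 1.7-fold higher number from compound 1 to compound 4 (0.23 log units; that floor lies within the scatter), so the one number in the set belongs to the compound with 2-chlorophenyl, though this floor does not separate the pair.

From the compounds shown here alone, it remains open how weak compound 2, compound 3 and compound 4 truly are. Going by these compounds, it also remains open whether an amine or a carboxylic acid on the carbonyl-bound phenyl ring would yield a measurable value.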